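Methoxy for Methyl on the Benzylidene Ring

The source may hold more compounds than are shown below. What is called first, only, known or untested is meant among the compounds shown, and "the series" means these compounds.

Compound 3 `CCCCCCCCCCCCCCNC(=O)[C@H](CO)/N=C/c1ccc(C)cc1` gives 102000 nM in a functional assay on cells (Homo sapiens) for cytotoxicity, read by MTT assay, with a stated time of 24 h (on this read-out higher numbers stand for weaker inhibition and lower numbers for stronger inhibition), the highest number of the three measured compounds. Compound 1 `CCCCCCCCCCCCCCNC(=O)[C@H](CO)/N=C/c1ccccc1` gives 7670 nM and compound 2 `CCCCCCCCCCCCCCNC(=O)[C@H](CO)/N=C/c1cccc(O)c1` gives 32600 nM in this assay. Compound 4 `CCCCCCCCCCCCCCNC(=O)[C@H](CO)/N=C/c1cccc(OC)c1` differs from compound 3 in one place: 3-methoxyphenyl in place of 4-methylphenyl on a carbon with a double bond to nitrogen. Among the measured compounds shown here, two measured steps bear on this change. The step of a 13-fold higher number from compound 1 to compound 3 (1.12 log units; beyond the scatter) shows how much the methyl on the aromatic carbon raised the number, and the step of a 3.1-fold higher number from compound 2 to compound 3 (0.50 log units; beyond the scatter) compares the 4-methylphenyl with a 3-hydroxyphenyl, the nearest measured relative of the 3-methoxyphenyl. A modest move to a lower number, landing between compound 2 and compound 3, is therefore expected. Compound 4 is estimated at 30000 nM (range 9000 nM to 90000 nM), an expected step of a 3.4-fold lower number from compound 3 to compound 4 (0.53 log units; beyond the scatter).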

Compound 4, half-maximal inhibitory concentration: 31300 nM
Beside the measured number, compound 4's estimate is 1.0-fold (0.02 log units) below it, and the stated range covers the measured number.
By their numbers in this assay, from the lowest: compound 1; then compounds 4 and 2 (each within the scatter of the next); then compound 3.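

Putting a methyl on the hydroxy oxygen changes little (a 1.0-fold lower number from compound 2 to compound 4 (0.02 log units; within the scatter)), so in this assay the hydroxy hydrogen makes no difference that can be told from scatter. The 3-methoxyphenyl still gives a higher number than the plain phenyl (a 4.1-fold higher number from compound 1 to compound 4 (0.61 log units; beyond the scatter)), though a lower one than the 4-methylphenyl (a 3.3-fold lower number from compound 3 to compound 4 (0.51 log units; beyond the scatter)). No measurement here explains these differences. The 4-methylphenyl and 3-methoxyphenyl differ in both group and ring position, so the two effects remain unseparated. On these data alone, whether an amine or a carboxylic acid on the ring would bring the number nearer that of compound 1 also stays open.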